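The compounds below may be only part of what the source reports. "The series", "measured", "known", "first", "only" and "open" are said of these compounds alone.

The series shares one core carrying a disulfide, and the compounds differ only in the group on the outer sulfur. Compound 1 `Cc1cn([C@H]2C[C@H](SSC(Cl)(Cl)Cl)[C@@H](CO)O2)c(=O)[nH]c1=O` carries trichloromethyl there; in a physicochemical assay for pharmacokinetics, at pH 7.2 (a lower number here means that the compound disappears faster, a higher number that the compound lasts longer), compound 1 gives < 0.0834 h, which is a limit of the assay and not a number. Compound 2 `Cc1cn([C@H]2C[C@H](SSc3ccc([N+](=O)[O-])cc3)[C@@H](CO)O2)c(=O)[nH]c1=O` carries 4-nitrophenyl; in this assay compound 2 gives < 0.0834 h, again a limit. Compound 3 `CCCCCCSS[C@H]1C[C@H](n2cc(C)c(=O)[nH]c2=O)O[C@@H]1CO` carries hexyl; in this assay compound 3 gives < 0.0834 h, also a limit. The steps a step that the two limits leave unreadable from compound 1 to compound 2, a step that the two limits leave unreadable from compound 1 to compound 3 and a step that the two limits leave unreadable from compound 2 to compound 3 therefore cannot be sized; all three values sit at the limit of < 0.0834 h in this assay, at which 3 of the 3 values shown sit. Compound 3 thus stands where the other two stand, at that limit, with no ordering among them.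

Compound 4 `Cc1cn([C@H]2C[C@H](SSCCN)[C@@H](CO)O2)c(=O)[nH]c1=O` is the next member; it differs from compound 3 by amino in place of butyl on a saturated chain carbon, two bonds along the chain from a sulfur. The measured steps bear on it only in that none of the three groups on the outer sulfur carried the half-life past the limit. Going by the values given here, no step gives a direction, so no change beyond the scatter is expected. The expected step in this assay is a step that the limit leaves unreadable from compound 3 to compound 4. For compound 4 the estimated value in this assay is 0.05 h, with a range from 0.01 h to 0.2 h, most likely reported once more as a limit.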

Compound 4, half-life: < 0.0834 h
Compound 4 ended at the assay's limit (the forecaster's own chance of this, stated with the estimate: 80%); the middle value is on the limit's open side.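

In this assay compound 4 gives < 0.0834 h, which is a limit of the assay and not a number. The steps joining compound 4 to compound 1, compound 2 and compound 3 therefore cannot be read, and the four compounds stand together: the limit of < 0.0834 h in this assay, at which 4 of the 4 values shown sit.

The compounds shown leave open how long any member lasts, and whether any group on the outer sulfur changes the half-life.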